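This account rests on a few compounds, and the source may have more. Where it says the series, first, only, none or still open, it means among the compounds named here.

Among the measured compounds shown here, in a physicochemical assay for solubility, read by HPLC, in phosphate buffer, at pH 6.5 (on this read-out lower numbers stand for lower solubility and higher numbers for higher solubility), compound 2 `COC(=O)C1=C(C)NC(c2nccs2)=NC1(C)c1ccc(S(C)(=O)=O)cc1` gives 365 ug/mL as the highest of two numbers so far, and compound 1 `COC(=O)C1=C(C)NC(c2nccs2)=NC1(C)c1ccc(Cl)cc1` gives 14 ug/mL on the same read-out. Compound 3 `COC(=O)C1=C(C)NC(c2nccs2)=NC1(C)c1ccc(OC)cc1` has methoxy in place of methylsulfonyl on an aromatic carbon, with the difference counted as methoxy in place of methylsulfonyl on an aromatic carbon in the two structures. For the measured compounds named here, the only measured step bearing on this is a 26-fold higher number from compound 1 to compound 2 (1.42 log units; beyond the scatter) with methylsulfonyl in place of chloro, and it is large. Methylsulfonyl leaves this time, so a large step down, somewhat smaller in size, is expected in this assay for this change. The estimated step is a 10-fold lower number from compound 2 to compound 3 (1.02 log units; beyond the scatter) on these grounds. Compound 3 is expected at 35 ug/mL with an estimated range of 12 ug/mL to 100 ug/mL on this read-out.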

Compound 3, solubility: 106 ug/mL
Beside the measured number, compound 3's estimate is 3.0-fold (0.48 log units) below it, outside the stated range (above it).
By their numbers in this assay, from the lowest: compound 1; then compound 3; then compound 2.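

In this assay, the three groups at this position, on an aromatic carbon para to a large group, give numbers that stand apart beyond the scatter, with a 3.4-fold lower number from compound 2 to compound 3 (0.54 log units; beyond the scatter) and a 7.6-fold higher number from compound 1 to compound 3 (0.88 log units; beyond the scatter) as the new steps. Methylsulfonyl is therefore not the only group in these compounds to give a higher number than chloro, although methoxy falls short of methylsulfonyl. Nothing available accounts for this order.

On these data alone, whether an amine or a carboxylic acid here would exceed methylsulfonyl remains open. So does whether this order of the three groups would hold with another change elsewhere on the shared core.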